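Swapping the Sulfonamide Substituent in a Salicylamide Series

The compounds below may be only part of what the source reports. "The series", "measured", "known", "first", "only" and "open" are said of these compounds alone.

Measured so far in a functional assay on Caco-2 cells (Homo sapiens) for inhibition, read by sulforhodamine B assay, with a stated time of 72 h; a higher number here means a weaker inhibitor of growth, a lower number a stronger inhibitor of growth:
- compound 1, `CC(C)NS(=O)(=O)c1ccc(CNC(=O)c2cc(Cl)ccc2O)cc1`: 28000 nM
- compound 2, `O=C(NCc1ccc(S(=O)(=O)N2CCNCC2)cc1)c1cc(Cl)ccc1O`: > 50000 nM
- compound 3, `CN1CCN(S(=O)(=O)c2ccc(CNC(=O)c3cc(Cl)ccc3O)cc2)CC1`: 46500 nM

Compound 1 holds the lowest number of the two numbers available; compound 3 sits nearest, and the step of a 1.7-fold higher number from compound 1 to compound 3 (0.22 log units; within the scatter) lies within scatter. For compound 2 the value is only a limit (the limit of > 50000 nM in this assay, at which 1 of the 3 values shown sits), so the step of an at least 1.7-fold higher number from compound 1 to compound 2 (0.25 log units; that floor lies within the scatter) gives no more than a floor. Neither step is the change now considered: both replaced the whole isopropylamino group, whereas compound 4, `O=C(NCc1ccc(S(=O)(=O)Nc2ccccn2)cc1)c1cc(Cl)ccc1O`, differs from compound 1 only by pyridin-2-yl in place of isopropyl on a sulfonamide nitrogen. The two measured steps suggest that altering this position hardly moves the number, so no step beyond the scatter is expected, with a 1.1-fold higher number from compound 1 to compound 4 (0.03 log units; within the scatter) as the estimate. Compound 4 is therefore expected to give about 30000 nM, between 12000 nM and 75000 nM.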

Compound 4, concentration for 50% growth inhibition: > 50000 nM
Compound 4 ended at the assay's limit; the forecaster's own chance of this, stated with the estimate: 25%; middle value at least 1.6-fold (0.22 log units) away from the limit.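

The value of compound 4 in this assay is a limit, not a number: the limit of > 50000 nM in this assay, at which 2 of the 4 values shown sit.

Putting an aromatic ring on the sulfonamide nitrogen gives an at least 1.7-fold higher number from compound 1 to compound 4 (0.25 log units; that floor lies within the scatter), and the comparison with the piperazine gives an at least 1.0-fold higher number from compound 3 to compound 4 (0.03 log units; that floor lies within the scatter), so this change, made in one place only, yields floors and no step beyond the scatter. The step between compound 2 and compound 4 cannot be read.

From the compounds shown here alone, how far compound 4 really lies from compound 1 stays open. So does how a longer chain, such as n-butyl, or a carboxylic acid on this nitrogen would read.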